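The compounds below may be only part of what the source reports. "The series", "measured", "known", "first", "only" and "open" are said of these compounds alone.

Of the compounds shown here, two have so far been tested in a functional assay on K562 cells (Homo sapiens) for antiproliferative activity, read by MTT assay, with a stated time of 48 h; on this read-out higher numbers stand for weaker inhibition and lower numbers for stronger inhibition. Compound 1 `Cc1ccc(-c2ccc3c(c2)C(=O)C(=O)N3)cc1` returned only a limit in this assay, > 10000 nM. That result is the limit of > 10000 nM in this assay, at which 1 of the 2 values shown sits, so the strength of compound 1 is not pinned to a number. Compound 2 `COc1ccc(-c2ccc3c(c2)C(=O)C(=O)N3Cc2ccc(Cl)c(Cl)c2)cc1` gave 430 nM in this assay. On the numbers shown, compound 2 therefore stands as the only compound with an actual value, and the other result, being a limit, offers no number to set against it.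

Compound 3 `COc1ccc(-c2ccc3c(c2)C(=O)C(=O)N3Cc2ccc(OC)c(OC)c2)cc1` has not yet been measured. It differs from compound 2 in one place: 3,4-dimethoxyphenyl in place of 3,4-dichlorophenyl on a saturated chain carbon bound to an amide-type nitrogen in a ring. Going by the values given here, no step between two measured compounds with this kind of change is available here, so the size of the step can only be estimated rather than read from data. The expectation is a modest step, more likely toward weaker inhibition than toward stronger, yet one that could well stay within the usual scatter of this assay.

Compound 3 is expected to give about 900 nM in this assay, with a plausible range from 300 nM to 3000 nM, which corresponds to an expected step of a 2.1-fold higher number from compound 2 to compound 3 (0.32 log units; beyond the scatter).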

Compound 3, half-maximal inhibitory concentration: 60 nM
For compound 3 the middle estimate is 15-fold (1.18 log units) above the measured one; measured number below the stated range.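

In this assay, replacing 3,4-dichlorophenyl with 3,4-dimethoxyphenyl on the saturated chain carbon bound to the amide-type nitrogen in the ring gives a 7.2-fold lower number from compound 2 to compound 3 (0.86 log units; beyond the scatter), the only step shown at this place. It shows that inhibition of cell growth responds to the group held here, by more than the usual scatter and toward stronger inhibition. Both groups keep the same six-membered aromatic ring of carbon only. On that ring the two chlorine atoms leave, and two methoxy groups enter, with the 2 hydrogen-bond acceptors counted for the new group.

No measured property among the results shown accounts for the size or direction of this step. Going by these compounds, one step also cannot tell whether the gain needs both methoxy groups, or whether a single methoxy group, a hydroxyl group or a fluorine atom on that ring would give a similar number, so how far the trend extends remains open.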